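A few compounds are considered here, and "the series" means these few. Any claim that something is new, unique, unknown or untested is made for them only; others in the source may bear on it.

Among the compounds with values here, compound 1 `CC/C=C\C/C=C\C/C=C\CCCCCCCc1cc(=O)c2c(O)c(C)c(O)c(C)c2o1` is one of three compounds measured in a functional assay on MCF7 cells (Homo sapiens) for antiproliferative activity, read by MTT assay (a lower number here means a stronger inhibitor, a higher number a weaker inhibitor), where compound 1 gives 17500 nM. Compound 3 `CCCCC/C=C\C/C=C\CCCCCCCc1cc(=O)c2c(O)cc(O)cc2o1` carries a core stripped of the two methyl groups of compound 1, and in this assay compound 3 gives 17500 nM, level with compound 1 within the scatter of the method. Compound 2 `CCCCC/C=C\C/C=C\CCCCCCCc1cc(=O)c2c(O)c(C)c(OCOC)c(C)c2o1`, in which one hydroxyl of the core is masked as a methoxymethyl ether, returns only a limit in this assay, > 84100 nM, so no number is known for it (the limit of > 84100 nM in this assay, at which 1 of the 3 values shown sits). Compound 4 `CCCCCCCCCCCCCCCc1cc(=O)c2c(O)c(C)c(O)c(C)c2o1` keeps the core of compound 1 unchanged and alters only the side chain, (a group of 8 heavy atoms (8 carbon; no ring) in place of a group of 10 heavy atoms (10 carbon; no ring), on a saturated chain carbon, seven bonds along the chain from an aromatic carbon). Within the data shown here, no measured pair in this set isolates such a change in the chain, so the size of the step is open; the account expects no shift beyond the scatter, with the step from the unsaturated chain to the octyl-terminated saturated chain in this assay estimated at a 1.3-fold higher number from compound 1 to compound 4 (0.10 log units; within the scatter). Compound 4 is therefore expected to give about 22000 nM in this assay, within a range of 8000 nM to 60000 nM.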

Compound 4, half-maximal inhibitory concentration: > 67200 nM
Compound 4 gave a limit, no number; the forecaster's own chance of this, stated with the estimate: 15%; at least 3.0-fold (0.48 log units) between middle value and limit.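

In this assay, changing the chain alone on the core of compound 1 is enough to move the reading: octyl in place of the group with three double bonds, on a saturated chain carbon, seven bonds along the chain from an aromatic carbon, gives an at least 3.8-fold higher number from compound 1 to compound 4 (0.58 log units; beyond the scatter). Within the data shown here, no earlier pair isolated a change in the chain, so this is the first sign that the core of compound 1 does not set the reading by itself. The reading for compound 4 is a limit and not a number: the limit of > 67200 nM in this assay, at which 1 of the 4 values shown sits.

The group that leaves and octyl differ both in their double bonds and in their carbon count, and the compounds shown do not separate the two. Going by these compounds, whether a longer saturated chain, or a chain ending in a carboxylic acid or an amine, would give a number in this assay also stays open.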